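The source may report more compounds than this note shows. Statements on the series, on what has been measured and on what is new or still open speak of the compounds shown alone.

Within the data shown here, compound 2 `CC(=O)OCCC(=O)O[C@H](CC=C(C)C)C1=CC(=O)c2c(O)ccc(O)c2C1=O` gives 17300 nM in a functional assay on HeLa cells (Homo sapiens) for cytotoxicity, read by MTT assay (a lower number here means a stronger inhibitor, a higher number a weaker inhibitor), the lowest of the two numbers so far; compound 1 `CC(C)=CC[C@@H](OC[C@H](C)O)C1=CC(=O)c2c(O)ccc(O)c2C1=O` gives 40300 nM. Among the measured compounds shown here, the step of a 2.3-fold lower number from compound 1 to compound 2 (0.37 log units; beyond the scatter) is the only one that bears on compound 3 `CC(C)=CC[C@@H](OCC(C)O)C1=CC(=O)c2c(O)ccc(O)c2C1=O`, which differs from compound 2 by 2-hydroxypropyl in place of (2-acetoxyethyl)carbonyl on an oxygen on a saturated carbon. Since this change reverses the same replacement, the number is expected to rise by about the same amount, so for compound 3 the step of a 2.3-fold higher number from compound 2 to compound 3 (0.36 log units; beyond the scatter) is expected. Compound 3 is therefore estimated at 40000 nM, with a range from 20000 nM to 80000 nM.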

Compound 3, half-maximal inhibitory concentration: 24700 nM
Compound 3: middle estimate off by 1.6-fold (0.21 log units), on the high side; low and high end bracket the measured number.
By their numbers in this assay, from the lowest: compounds 2, 3 and 1 (each within the scatter of the next, the first and the last beyond it).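

In this assay, putting 2-hydroxypropyl in place of (2-acetoxyethyl)carbonyl on this oxygen now gives a 1.4-fold higher number from compound 2 to compound 3 (0.15 log units; within the scatter), so this reading of the change does not clear the scatter. The two 2-hydroxypropyl compounds give a 1.6-fold lower number from compound 1 to compound 3 (0.21 log units; within the scatter), so how the stereocentre is drawn makes no difference beyond the scatter here. This pair is read with one caution: the fact that one of compounds 1 and 3 is drawn with a defined configuration and the other without, at the place where they differ

From the compounds shown here alone, it remains open how a single defined configuration at that carbon compares with its mirror arrangement. Also open, going by these compounds, is whether an amine or a longer chain on this oxygen would shift the number.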